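Carbamoyl for trifluoromethyl on the pendant aromatic ring

The compounds below may be only part of what the source reports. "The series", "measured", "known", "first", "only" and "open" are said of these compounds alone.

Of the compounds shown here, three sharing one core have been measured in an assay for inhibition of MAP kinase-interacting serine/threonine-protein kinase 1 (Homo sapiens), read by luminescence and ADP-Glo, with a stated time of 2 h; on this read-out higher numbers stand for weaker inhibition and lower numbers for stronger inhibition. Compound 1 `Nc1n[nH]c2cc(-c3ccc(=O)n(Cc4ccccc4)c3)ccc12` gives 79 nM, compound 2 `O=c1ccc(-c2ccc3cn[nH]c3c2)cn1Cc1ccccc1C(F)(F)F` gives 133 nM, and compound 3 `CC(=O)Nc1cccc(Cn2cc(-c3ccc4c(N)n[nH]c4c3)ccc2=O)c1` gives 55 nM. Compound 2 has the highest of the three numbers; against compound 1 it differs by an amount within the scatter, while its gap to compound 3 lies beyond it. Among the compounds with values here, the one single-point step seen so far, a 1.4-fold lower number from compound 1 to compound 3 (0.16 log units; within the scatter), puts acetamido in place of hydrogen on an aromatic carbon and stays within the scatter.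

Compound 4 `NC(=O)c1ccccc1Cn1cc(-c2ccc3cn[nH]c3c2)ccc1=O` is drawn from compound 2 by the change (carbamoyl in place of trifluoromethyl on an aromatic carbon). Within the data shown here, no measured step replaces trifluoromethyl, so the closest guide is the step from compound 1 to compound 3, where a group carrying a hydrogen-bond donor and acceptor entered on an aromatic carbon without a change beyond the scatter. On that basis compound 4 is expected to lie close to compound 2, with the step of a 1.3-fold lower number from compound 2 to compound 4 (0.12 log units; within the scatter) estimated to stay within the scatter. Compound 4 is therefore estimated at 100 nM in this assay, with a range of 40 nM to 260 nM.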

Compound 4, half-maximal inhibitory concentration: 878 nM
Beside the measured number, compound 4's estimate is 8.8-fold (0.94 log units) below it, outside the stated range (above it).
By their numbers in this assay, from the lowest: compounds 3, 1 and 2 (each within the scatter of the next, the first and the last beyond it); then compound 4.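

In this assay, carbamoyl in place of trifluoromethyl on this aromatic carbon, ortho to a large group, produces a 6.6-fold higher number from compound 2 to compound 4 (0.82 log units; beyond the scatter), so the number at this position depends on which of the two groups it carries. Within the data shown here, this is the first single-point step to go beyond the scatter, whereas acetamido in place of hydrogen, in the step of a 1.4-fold lower number from compound 1 to compound 3 (0.16 log units; within the scatter), stayed within it, so an added group on the pendant aromatic ring is not always without effect. Nothing available here bears on why the number rises.

As far as these compounds go, whether a nitrile, a methyl group or a carboxylic acid on this carbon would stay near compound 2 or move towards compound 4 remains open. From the compounds shown here alone, it is also open whether carbamoyl would give a step of similar size on the core of compound 1.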